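Replacing a saturated ring with pyridine in compound 2

This account rests on a few compounds, and the source may have more. Where it says the series, first, only, none or still open, it means among the compounds named here.

Compound 1 `CC(C)CCCN(C)Cc1ccc(C2CCCN(C)C2)cc1` gives > 50000 nM
Compound 2 `CN(C/C=C/c1ccccc1)Cc1ccc(C2CCCN(C)C2)cc1` gives > 50000 nM

Both readings come from an ADME assay on HL-60 cells (Homo sapiens) for cytotoxicity, read by MTT assay, with a stated time of 24 h (a lower number here means a stronger inhibitor, a higher number a weaker inhibitor), and neither is a number. Compound 2 stands at > 50000 nM, which is a limit of the assay. The whole record so far is the limit of > 50000 nM in this assay, at which 2 of the 2 values shown sit.

Compound 3 `CN(C/C=C/c1ccccc1)Cc1ccc(-c2cccnc2)cc1` differs from compound 2 in one place: pyridin-3-yl in place of 1-methylpiperidin-3-yl on an aromatic carbon. In short, pyridin-3-yl sits in place of 1-methylpiperidin-3-yl on an aromatic carbon.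

Within the data shown here, the only measured step, a step that the two limits leave unreadable from compound 1 to compound 2, lies at a different place and its size cannot be read, so it sets neither a size nor a direction. The expectation therefore starts from compound 2 at > 50000 nM, again only a limit. No change beyond the usual scatter is expected, and the estimated step is a number no higher from compound 2 to compound 3 (the limit leaves the size open). Compound 3 is estimated at 50000 nM, with an expected range from 20000 nM to 120000 nM.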

Compound 3, half-maximal inhibitory concentration: 44000 nM
The estimate for compound 3 lay 1.1-fold (0.06 log units) above the measured number; low and high end bracket the measured number.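

Compound 3, which carries pyridin-3-yl in place of 1-methylpiperidin-3-yl on an aromatic carbon, gives a true number in this assay: 44000 nM. Compound 2 stands at > 50000 nM, which is a limit and not a number. The change therefore reads only as an at least 1.1-fold lower number from compound 2 to compound 3 (0.05 log units; that floor lies within the scatter), so this position can take an aromatic ring and still give a reading near the limit, with no step shown beyond the scatter.

Going by these compounds, how far the true step reaches stays open, as most of the record is still not a number: the limit of > 50000 nM in this assay, at which 2 of the 3 values shown sit. Also open, on these data alone, is how a phenyl, a pyridin-4-yl or a carboxylic acid on this same aromatic carbon would read in this assay.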